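The source may report more compounds than this note shows. Statements on the series, on what has been measured and on what is new or still open speak of the compounds shown alone.

Series of three measured amides on a shared core, read in a toxicity assay on THP-1 cells (Homo sapiens) for inhibition; on this read-out lower numbers stand for higher toxicity in this test and higher numbers for lower toxicity in this test. Compound 1 `Cn1c(-c2ccc(C#N)cc2)cnc1NC(=O)c1ccc(F)cc1` reaches only the assay limit and gives > 50000 nM in this assay. Compound 2 `Cn1c(-c2ccccc2)cnc1NC(=O)c1ccccc1` likewise returns a limit, giving > 100000 nM. Compound 3 `COc1ccc(-c2cnc(NC(=O)c3cccc(OC)c3)n2C)cc1` also stops at a limit, giving > 100000 nM. Compound 1 therefore stands among values that are all limits: the three values are the limit of > 100000 nM in this assay, at which 2 of the 3 values shown sit, and (the limit of > 50000 nM in this assay, at which 1 of the 3 values shown sits), so no order among compounds 1, 2 and 3 can be drawn. Compound 4 `Cn1c(-c2cccc(F)c2)cnc1NC(=O)c1ccc(F)cc1` is the unmeasured member; relative to compound 1 the change is 3-fluorophenyl in place of 4-cyanophenyl on an aromatic carbon. For the measured compounds named here, no measured step between any pair of compounds is available, so the size of the move cannot be read off the data. Since compound 1 already sits at a limit, no shift beyond the scatter is expected, and the expected step is a step that the limit leaves unreadable from compound 1 to compound 4, small in either direction. Compound 4 is thus estimated at 60000 nM, within 20000 nM to 200000 nM, and most probably it too will be reported only as a limit.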

Compound 4, half-maximal cytotoxic concentration: 58000 nM
The estimate for compound 4 lay 1.0-fold (0.01 log units) above the measured number; the range from low to high includes it.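

Compound 1 gives only a limit in this assay, > 50000 nM. For the compounds shown here, no step from compound 1 to compound 4 can therefore be read. The compounds shown leave open whether 3-fluorophenyl in place of 4-cyanophenyl changes the half-maximal cytotoxic concentration at all.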